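Extending the Acrylamide Chain on a Fluoroindole Core

The source may hold more compounds than are shown below. What is called first, only, known or untested is meant among the compounds shown, and "the series" means these compounds.

Measured so far, in a functional assay on NCI-H1975 cells (Homo sapiens) for antiproliferative activity, read by MTT assay, with a stated time of 72 h; a lower number here means a stronger inhibitor, a higher number a weaker inhibitor:
Compound 1 `C=CC(=O)Nc1cc(Nc2nc(C)cc(-c3cn(C)c4ccccc34)n2)c(OC)cc1N(C)CCN(C)C` gives 4810 nM.
Compound 2 `CC/C=C\C(=O)Nc1cc(Nc2nc(C)cc(-c3cn(C)c4ccccc34)n2)c(OC)cc1N(C)CCN(C)C` gives 1990 nM.
Compound 3 `C=CC(=O)Nc1cc(Nc2nccc(-c3cn(C)c4ccc(F)cc34)n2)c(OC)cc1N(C)CCN(C)C` gives 254 nM.

Compounds 1 and 2 share a core and differ in one place: but-1-en-1-yl in place of vinyl on a carbonyl carbon. That change gave a 2.4-fold lower number from compound 1 to compound 2 (0.38 log units; beyond the scatter). Compound 3 carries a different core, and how it differs from compound 1 is not broken down here. Among the three measured compounds, compound 3 has the lowest number, and its steps to the other two lie beyond the scatter.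

Compound 4 `CC/C=C\C(=O)Nc1cc(Nc2nccc(-c3cn(C)c4ccc(F)cc34)n2)c(OC)cc1N(C)CCN(C)C` is not yet measured. It differs from compound 3 by but-1-en-1-yl in place of vinyl on a carbonyl carbon, the same change as from compound 1 to compound 2, made at the same place. If the change behaves on the core of compound 3 as it did on the core of compound 1, compound 4 is expected to show a 2.1-fold lower number from compound 3 to compound 4 (0.33 log units; beyond the scatter) in this assay, a step of a size similar to the earlier one. This rests on a single measured pair, so the range is kept wide. Compound 4 is therefore estimated at 120 nM, between 50 nM and 300 nM.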

Compound 4, half-maximal inhibitory concentration: 2600 nM
Beside the measured number, compound 4's estimate is 22-fold (1.34 log units) below it; the measured number lies above the stated range.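

On the core of compound 3, putting but-1-en-1-yl in place of vinyl on a carbonyl carbon gave a 10-fold higher number from compound 3 to compound 4 (1.01 log units; beyond the scatter) in this assay. The same change therefore moved the number in opposite directions on the two cores, so in this series its effect on one core cannot be assumed to hold on the other: the same change on two cores in this assay, a 2.4-fold lower number (0.38 log units; beyond the scatter) from compound 1 to compound 2 and a 10-fold higher number (1.01 log units; beyond the scatter) from compound 3 to compound 4, 25-fold (1.39 log units) apart, beyond the scatter of two such steps These two pairs show that the core matters to the outcome, but they do not show why, or which part of the difference between the two cores is responsible.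

For the compounds shown here, compounds that change only one part of the core at a time, with vinyl and but-1-en-1-yl compared on each, would be needed to settle that point, and the behaviour of the change on any further core remains open. Also open, as far as these compounds go, is how a longer chain, or a chain carrying an amine, would behave in place of vinyl on a carbonyl carbon on either core.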